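This account rests on a few compounds, and the source may have more. Where it says the series, first, only, none or still open, it means among the compounds named here.

Compound 1 `COc1ccc(C2CC(Nc3nc4ccc([N+](=O)[O-])cc4s3)=NN2C(C)=O)cc1O` is measured in a functional assay on the whole organism (Hindlimb, strain albino) with Mus musculus as the target, in the maximal electroshock model, with a stated time of 0.5 h (a higher number here means that more compound is needed for the effect, a lower number that less compound is needed), where compound 1 gives 178 umol/kg. Compound 2 `CC(=O)N1N=C(Nc2nc3ccc([N+](=O)[O-])cc3s2)CC1c1ccc(O)cc1` differs from it in one place, (4-hydroxyphenyl in place of 3-hydroxy-4-methoxyphenyl on a saturated ring carbon). In this assay compound 2 gives 162 umol/kg. The step between the two is a 1.1-fold lower number from compound 1 to compound 2 (0.04 log units; within the scatter). Compound 3 `COc1ccc(C2CC(Nc3nc4ccccc4s3)=NN2C(C)=O)cc1O` carries a different core, and the difference between the cores is hydrogen in place of nitro on an aromatic carbon. In this assay compound 3 gives 259 umol/kg. The step from the first core to the second is a 1.5-fold higher number from compound 1 to compound 3 (0.16 log units; within the scatter). Compound 4 `CC(=O)N1N=C(Nc2nc3ccccc3s2)CC1c1ccc(O)cc1` has not yet been measured. It stands to compound 3 as compound 2 stands to compound 1: the change is 4-hydroxyphenyl in place of 3-hydroxy-4-methoxyphenyl on a saturated ring carbon, and the place is described in exactly the same words as for the earlier pair, so this is the same change, now made on the core of compound 3. Because that earlier instance of the change gave a 1.1-fold lower number from compound 1 to compound 2 (0.04 log units; within the scatter), compound 4 is expected to show a step of a 1.1-fold lower number from compound 3 to compound 4 (0.04 log units; within the scatter). For compound 4 the estimate is 235 umol/kg, with a likely range from 120 umol/kg to 470 umol/kg.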

Compound 4, dose for half-maximal effect: 249 umol/kg
For compound 4 the middle estimate is 1.1-fold (0.03 log units) below the measured one, and the stated range covers the measured number.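

In this assay, putting 4-hydroxyphenyl in place of 3-hydroxy-4-methoxyphenyl gives a 1.0-fold lower number from compound 3 to compound 4 (0.02 log units; within the scatter), and this agrees with the earlier instance of the change: the same change on two cores in this assay, a 1.1-fold lower number (0.04 log units; within the scatter) from compound 1 to compound 2 and a 1.0-fold lower number (0.02 log units; within the scatter) from compound 3 to compound 4, 1.1-fold (0.02 log units) apart, within the scatter of two such steps. Putting hydrogen in place of nitro gives a 1.5-fold higher number from compound 2 to compound 4 (0.19 log units; within the scatter), and this also agrees with its earlier instance: the same change on two cores in this assay, a 1.5-fold higher number (0.16 log units; within the scatter) from compound 1 to compound 3 and a 1.5-fold higher number (0.19 log units; within the scatter) from compound 2 to compound 4, 1.1-fold (0.02 log units) apart, within the scatter of two such steps. Among the compounds shown here, each change therefore reads the same on both cores, but every step lies within the scatter, so the series shows only that neither change visibly moves the number here, not that a change with a clear effect would carry over from one core to another in the same way.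

The compounds shown leave open whether an amine or a carboxylic acid in place of nitro, or a longer chain in place of the acetyl group, would give a step beyond the scatter in this assay. They also leave open whether the agreement between the two cores would hold for such a step.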